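Chloro for bromo on the aryl thioether of compound 3

The source may hold more compounds than are shown below. What is called first, only, known or untested is meant among the compounds shown, and "the series" means these compounds.

For the measured compounds named here, compound 3 `OC[C@H]1O[C@@H](n2cnc3c(CSc4ccccc4Br)ncnc32)[C@H](O)[C@@H]1O` gives the lowest number so far in an assay on isolated protein for binding affinity to Equilibrative nucleoside transporter 1 (Homo sapiens) (a lower number here means a stronger inhibitor, a higher number a weaker inhibitor), at 2400 nM. In this assay compound 1 `OC[C@H]1O[C@@H](n2cnc3c(NCc4ccco4)ncnc32)[C@H](O)[C@@H]1O` gives 36300 nM and compound 2 `Cc1cccc(CSc2ncnc3c2ncn3[C@@H]2O[C@H](CO)[C@@H](O)[C@H]2O)c1` gives 12000 nM. The steps of a 15-fold lower number from compound 1 to compound 3 (1.18 log units; beyond the scatter) and a 5.0-fold lower number from compound 2 to compound 3 (0.70 log units; beyond the scatter) each exchange the entire substituent on the shared core, as does a 3.0-fold lower number from compound 1 to compound 2 (0.48 log units; beyond the scatter). Compound 4 `OC[C@H]1O[C@@H](n2cnc3c(CSc4ccccc4Cl)ncnc32)[C@H](O)[C@@H]1O` keeps the ((2-bromophenyl)sulfanyl)methyl arm apart from chloro in place of bromo on an aromatic carbon. Going by the values given here, no measured step isolates an exchange of one halogen for another, so none of the three steps bears on it directly, and all three are far larger changes. For compound 4 a step of a 1.1-fold higher number from compound 3 to compound 4 (0.03 log units; within the scatter) is expected, within the scatter of this assay. Compound 4 is thus estimated at 2600 nM, with a range from 1000 nM to 7000 nM.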

Compound 4, half-maximal inhibitory concentration: 1780 nM
The estimate for compound 4 lay 1.5-fold (0.16 log units) above the measured number; measured number inside the range.
By their numbers in this assay, from the lowest: compounds 4 and 3 (each within the scatter of the next); then compound 2; then compound 1.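

Chloro in place of bromo on an aromatic carbon, ortho to a large group, gives a 1.3-fold lower number from compound 3 to compound 4 (0.13 log units; within the scatter), so this assay does not separate these two halogens at this position. The ((2-chlorophenyl)sulfanyl)methyl arm stays well ahead of the other substituents, with a 6.7-fold lower number from compound 2 to compound 4 (0.83 log units; beyond the scatter) and a 20-fold lower number from compound 1 to compound 4 (1.31 log units; beyond the scatter) on exchange of the entire substituent. Nothing at hand gives a cause for these results.

Going by these compounds, whether a halogen is needed here at all remains open. Hydrogen, fluoro, methoxy or an amine on this aromatic carbon would address that question.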